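A few compounds are considered here, and "the series" means these few. Any claim that something is new, unique, unknown or untested is made for them only; others in the source may bear on it.

Compound 2 `COc1ccc(-c2cc(/C=C/C(=O)c3ccc(C)c(C)c3)nc3cc(-c4ccccc4)nn23)cc1OC` gives 12100 nM in a functional assay on DU-145 cells (Homo sapiens) for antiproliferative activity, read by MTT assay, with a stated time of 24 h (on this read-out lower numbers stand for stronger inhibition and higher numbers for weaker inhibition), the lowest of the two numbers recorded so far. Among the measured compounds shown here, the only other measured compound, compound 1 `COc1ccc(-c2cc(/C=C/C(=O)c3ccc(C)cc3)nc3cc(-c4ccccc4)nn23)cc1OC`, gives 26800 nM in this assay. For the measured compounds named here, the single measured step between them, a 2.2-fold lower number from compound 1 to compound 2 (0.35 log units; beyond the scatter), is the only comparison available to guide expectations. Compound 3 `COc1ccc(C(=O)/C=C/c2cc(-c3ccc(OC)c(OC)c3)n3nc(-c4ccccc4)cc3n2)cc1` has not yet been measured; it differs from compound 2 in that (4-methoxyphenyl in place of 3,4-dimethylphenyl on a carbonyl carbon). This change removes both methyl groups and introduces a methoxy group, for which no measured step exists among these compounds. Because a 2.2-fold lower number from compound 1 to compound 2 (0.35 log units; beyond the scatter) was modest, losing the methyls is expected to move the number back up by a similar modest amount, with the methoxy left as an unknown. The expected step is therefore a 1.7-fold higher number from compound 2 to compound 3 (0.22 log units; within the scatter). Compound 3 is estimated at 20000 nM, with a likely range from 7000 nM to 55000 nM.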

Compound 3, half-maximal inhibitory concentration: 14600 nM
Compound 3: middle estimate off by 1.4-fold (0.14 log units), on the high side; measured number inside the range.
By their numbers in this assay, from the lowest: compounds 2, 3 and 1 (each within the scatter of the next, the first and the last beyond it).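

In this assay, a 4-methoxyphenyl on the carbonyl carbon does about as well as a 3,4-dimethylphenyl, with a 1.2-fold higher number from compound 2 to compound 3 (0.08 log units; within the scatter) as the step between them. Methoxy in place of methyl on an aromatic carbon gives a 1.8-fold lower number from compound 1 to compound 3 (0.26 log units; within the scatter) as its step, so this change also stays within the usual variation between repeat measurements. Compound 3 therefore cannot be told apart from either neighbour, even though compound 1 and compound 2 differ beyond that variation, and this position accepts an oxygen-linked group here without a clear change in the number.

Nothing given here explains these numbers. From the compounds shown here alone, it remains open whether an amine, a carboxylic acid or a chlorine atom on this ring would shift the number beyond the scatter.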